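The source may report more compounds than this note shows. Statements on the series, on what has been measured and on what is new or still open speak of the compounds shown alone.

Of the compounds shown here, three have been tested so far in a functional assay on HL-60 cells (Homo sapiens) for cytotoxicity, read by MTT assay; a lower number here means a stronger inhibitor, a higher number a weaker inhibitor. Compound 1, `Oc1ccc(O)c(COCc2cc(O)cc(Cl)c2O)c1`, gives 6100 nM in this assay. Compound 2, `Oc1ccc(O)c(COCc2cc(O)ccc2O)c1`, gives 5500 nM in this assay. The two differ by hydrogen in place of chloro on an aromatic carbon, and that change made a step of a 1.1-fold lower number from compound 1 to compound 2 (0.04 log units; within the scatter). Compound 3, `COCc1cc(O)cc(Cl)c1O`, gives 6700 nM in this assay; its gaps to compound 1 and to compound 2 are both within the scatter, so no order among the three can be read. The difference between the core of compound 3 and the core of compound 1 is not broken down here.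

Compound 4, `COCc1cc(O)ccc1O`, has not yet been measured. It differs from compound 3 by hydrogen in place of chloro on an aromatic carbon. For the measured compounds named here, this is the same kind of change as the one between compound 1 and compound 2, though the surroundings differ: in compound 1 the site is meta to a large group, in compound 3 it is meta to a methoxymethyl group (3 heavy atoms). A similar step, a 1.1-fold lower number from compound 3 to compound 4 (0.03 log units; within the scatter), is expected in this assay, because a 1.1-fold lower number from compound 1 to compound 2 (0.04 log units; within the scatter) lay within the scatter. Compound 4 is therefore estimated at 6300 nM, with a likely range from 3000 nM to 13000 nM.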

Compound 4, half-maximal inhibitory concentration: 58900 nM
For compound 4 the middle estimate is 9.3-fold (0.97 log units) below the measured one, outside the stated range (above it).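

In this assay, putting hydrogen in place of the chloro group gave an 8.8-fold higher number from compound 3 to compound 4 (0.94 log units; beyond the scatter), so this change on the core of compound 3 did not repeat what it did on the core of compound 1, and the two results truly differ: the same change on two cores in this assay, a 1.1-fold lower number (0.04 log units; within the scatter) from compound 1 to compound 2 and an 8.8-fold higher number (0.94 log units; beyond the scatter) from compound 3 to compound 4, 9.8-fold (0.99 log units) apart, beyond the scatter of two such steps. For the compounds shown here, the size of this change on one core therefore cannot be carried over to the other, and an estimate taken from compound 1 and compound 2 is no safe guide for compounds built like compound 3. Going by these compounds alone, this comparison rests on only two pairs, however, so it shows that the core matters without showing which part of it matters or why.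

The compounds shown leave open whether another group on that aromatic carbon, such as bromo, methyl or an amine, would follow compound 3 and compound 4 or compound 1 and compound 2. They also leave open what the same change does when a longer chain stands in place of the methoxymethyl group.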